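A few compounds are considered here, and "the series" means these few. Any claim that something is new, unique, unknown or untested is made for them only; others in the source may bear on it.

Measured so far in a functional assay on SN12C cells (Homo sapiens) for inhibition, read by sulforhodamine B assay, with a stated time of 48 h; a higher number here means that more compound is tolerated, a lower number that less compound is tolerated:

Compound 1 `O=C(Nc1cccc(-n2cc(-c3ccncc3)c(-c3ccc(Cl)c(O)c3)n2)c1)Nc1ccc(Cl)c(Cl)c1`: in this assay compound 1 gives > 32500 nM, which is a limit of the assay and not a number.
Compound 2 `COc1cc(-c2nn(-c3cccc(NC(=O)c4cccc(C(F)(F)F)c4)c3)cc2-c2ccncc2)ccc1Cl`: compound 2 gives > 50000 nM, again a limit.
Compound 3 `O=C(Nc1cccc(-n2cc(-c3ccncc3)c(-c3ccc(Cl)c(O)c3)n2)c1)Nc1cc(C(F)(F)F)cc(C(F)(F)F)c1`: compound 3 gives > 50000 nM, also a limit.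

None of the three compounds reaches a measured value; every result is a limit. Compound 2 stands at the limit of > 50000 nM in this assay, at which 2 of the 3 values shown sit, and compound 1 sits at the limit of > 32500 nM in this assay, at which 1 of the 3 values shown sits. Among the compounds with values here, there is no measured pair of compounds that differ in a single place, so no step size has been observed in this assay.

Compound 4 `COc1cc(-c2nn(-c3cccc(NC(=O)c4ccccc4)c3)cc2-c2ccncc2)ccc1Cl` has not yet been measured. It differs from compound 2 by a single change: hydrogen in place of trifluoromethyl on an aromatic carbon. Since every measured compound, including compound 2, only gives a limit, the step from compound 2 to compound 4 is expected to stay within the scatter, and compound 4 is expected to remain at a limit as well, with a number no higher from compound 2 to compound 4 (the limit leaves the size open) as the expected step. The estimate for compound 4 is 50000 nM, expected to lie between 20000 nM and 100000 nM.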

Compound 4, concentration lethal to 50% of the cells: > 100000 nM
Compound 4: no number, only a limit; the forecaster's own chance of this, stated with the estimate: 85%; middle value at least 2.0-fold (0.30 log units) from the limit.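

In this assay, compound 2 and compound 4 each give only a limit of the assay and not a number, so no step can be read between them. The compounds shown leave open what number any of them would give, and whether hydrogen in place of trifluoromethyl changes it.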